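A few compounds are considered here, and "the series" means these few. Any claim that something is new, unique, unknown or untested is made for them only; others in the source may bear on it.

Measured so far in a functional assay on K562 cells (Homo sapiens) for antiproliferative activity, with a stated time of 72 h; on this read-out higher numbers stand for weaker inhibition and lower numbers for stronger inhibition:
compound 1 `OC[C@H]1O[C@@H](n2cnc3c(NCc4ccc(F)cc4)ncnc32)[C@H](O)[C@@H]1O`: 2700 nM
compound 2 `OC[C@H]1O[C@@H](n2cnc3c(NCc4ccc(Cl)cc4)ncnc32)[C@H](O)[C@@H]1O`: 218000 nM
compound 3 `COc1ccccc1CNc1ncnc2c1ncn2[C@@H]1O[C@H](CO)[C@@H](O)[C@H]1O`: 89000 nM

Compound 3 holds the second highest of the three numbers. Its nearest neighbour is compound 2, the gap being a 2.4-fold lower number from compound 2 to compound 3 (0.39 log units; beyond the scatter); furthest away is compound 1, with a 33-fold higher number from compound 1 to compound 3 (1.52 log units; beyond the scatter) between them. Compound 4 `OC[C@H]1O[C@@H](n2cnc3c(NCc4c(F)ccc(F)c4F)ncnc32)[C@H](O)[C@@H]1O` differs from compound 3 in one place: 2,3,6-trifluorophenyl in place of 2-methoxyphenyl on a saturated chain carbon bound to a nitrogen on an aromatic ring. Within the data shown here, the steps that bear on this change are the two earlier swaps of the aryl group on that chain carbon, a 33-fold higher number from compound 1 to compound 3 (1.52 log units; beyond the scatter) and a 2.4-fold lower number from compound 2 to compound 3 (0.39 log units; beyond the scatter), together with an 81-fold higher number from compound 1 to compound 2 (1.91 log units; beyond the scatter), which shows that even a single halogen exchange on the ring shifts the number a long way in this set. Among the measured compounds shown here, the only fluorinated analogue, compound 1, carries the lowest number, but its fluorine pattern differs from the 2,3,6-trifluorophenyl of compound 4, so the size of the step is uncertain. A lower number than for compound 3 is nevertheless expected, namely an 8.9-fold lower number from compound 3 to compound 4 (0.95 log units; beyond the scatter). Compound 4 is estimated at 10000 nM, within a range from 1500 nM to 70000 nM.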

Compound 4, half-maximal inhibitory concentration: > 166000 nM
Compound 4: only a limit was reported; the forecaster's own chance of this, stated with the estimate: 5%; at least 16-fold (1.22 log units) between middle value and limit.
By their numbers in this assay, from the lowest: compound 1; then compound 3; then compound 2.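

In this assay compound 4 gives a limit and not a number: the limit of > 166000 nM in this assay, at which 1 of the 4 values shown sits. Adding fluorines to the aryl group on this saturated chain carbon does not carry over the low number of the 4-fluorophenyl compound, as an at least 61-fold higher number from compound 1 to compound 4 (1.78 log units; beyond the scatter) shows, so in this set a fluorinated ring alone does not secure it, and compound 1 remains the strongest of the four. The 2,3,6-trifluorophenyl for 2-methoxyphenyl change gives an at least 1.8-fold higher number from compound 3 to compound 4 (0.27 log units; that floor lies within the scatter), a floor too small to set those two apart, while the step from compound 2 to compound 4 cannot be read.

As far as these compounds go, how far the true number of compound 4 lies past its limit stays open. Also open, from the compounds shown here alone, is whether the low number of compound 1 would survive a cyclohexyl group or a pyridine ring in place of the aryl group at this position.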